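Indole methoxy removal in the dichloroquinone bis-indole series

This account rests on a few compounds, and the source may have more. Where it says the series, first, only, none or still open, it means among the compounds named here.

The series pairs two indol-3-yl groups on a dihalogenated quinone. Compound 1 `Cc1ccc(-c2[nH]c3ccccc3c2C2=C(Br)C(=O)C(c3c(C)[nH]c4ccccc34)=C(Br)C2=O)cc1` carries bromine on the quinone and in a functional assay on MDA-MB-231 cells (Homo sapiens) for antiproliferative activity, read by CCK-8 assay, with a stated time of 48 h (a lower number here means a stronger inhibitor, a higher number a weaker inhibitor), compound 1 gives 6.67 ug/mL. Compound 2 `Cc1[nH]c2ccccc2c1C1=C(Cl)C(=O)C(c2c(-c3ccccc3)[nH]c3ccccc23)=C(Cl)C1=O` carries chlorine and in this assay compound 2 gives 4.46 ug/mL. Compound 3 `COc1ccc2[nH]c(C)c(C3=C(Cl)C(=O)C(c4c(-c5ccc(C)cc5)[nH]c5ccccc45)=C(Cl)C3=O)c2c1` adds a methoxy group to one indole and in this assay compound 3 gives 4.15 ug/mL, the lowest of the three numbers, though its gap to compound 2 and its gap to compound 1 both lie within the scatter, so no order among the three can be read.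

Compound 4 `Cc1ccc(-c2[nH]c3ccccc3c2C2=C(Cl)C(=O)C(c3c(C)[nH]c4ccccc34)=C(Cl)C2=O)cc1` differs from compound 3 by hydrogen in place of methoxy on an aromatic carbon, placing hydrogen in place of methoxy on an aromatic carbon; the rest is unchanged. For the measured compounds named here, no measured pair shows this exact change. Since compounds 1, 2 and 3 all sit within the scatter of one another despite differing substituents, the step from compound 3 to compound 4 is expected to be small, a 1.2-fold higher number from compound 3 to compound 4 (0.08 log units; within the scatter), with no direction beyond the scatter. Compound 4 is therefore estimated at 5 ug/mL, within 2.5 ug/mL to 10 ug/mL.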

Compound 4, half-maximal inhibitory concentration: 4.21 ug/mL
Estimate against measurement, compound 4: 1.2-fold (0.07 log units) above, within the range that was stated.
By their numbers in this assay, from the lowest: compounds 3, 4, 2 and 1 (each within the scatter of the next).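

In this assay, for the compounds shown here, the change from 5-methoxy-2-methyl-1H-indol-3-yl to 2-methyl-1H-indol-3-yl gives a 1.0-fold higher number from compound 3 to compound 4 (0.01 log units; within the scatter) and is the first direct reading at this position, where methoxy and hydrogen cannot be told apart. A second single change, methyl in place of hydrogen on an aromatic carbon, gives a 1.1-fold lower number from compound 2 to compound 4 (0.03 log units; within the scatter) and likewise separates nothing. No supporting data bear on either result.

Neither step shows whether this position can move the number at all, since only methoxy and hydrogen are compared there. An amine, a carboxylic acid or a longer alkoxy chain at the same aromatic carbon would test whether the position responds to a more different group.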